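Ethoxyphenyl Placement in Four Antiproliferative Analogues

The source may hold more compounds than are shown below. What is called first, only, known or untested is meant among the compounds shown, and "the series" means these compounds.

Four compounds share a large fused core and differ in the ethoxyphenyl group carried on an aromatic nitrogen, and in the core itself. Compound 1 `CCOc1ccccc1-n1nncc1CN1C(=O)C2(C(C#N)=C(N)Oc3c2c2nc4ccccc4nc2c2ccccc32)c2ccccc21` bears a 2-ethoxyphenyl, while compound 2 `CCOc1ccc(-n2nncc2CN2C(=O)C3(C(C#N)=C(N)Oc4c3c3nc5ccccc5nc3c3ccccc43)c3ccccc32)cc1` bears a 4-ethoxyphenyl on the same core. In a functional assay on HepG2 cells (Homo sapiens) for antiproliferative activity, read by MTT assay, with a stated time of 48 h (on this read-out higher numbers stand for weaker inhibition and lower numbers for stronger inhibition), compound 1 gives > 50000 nM, which is a limit of the assay and not a number. In this assay compound 2 gives > 50000 nM, again a limit. The change from compound 2 to compound 1 is 2-ethoxyphenyl in place of 4-ethoxyphenyl on an aromatic nitrogen, and the step it made, a step that the two limits leave unreadable from compound 2 to compound 1, cannot be read because of the limit of > 50000 nM in this assay, at which 3 of the 3 values shown sit.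

Compound 3 `CCOc1ccc(-n2nncc2CN2C(=O)C3(C(C#N)=C(N)Oc4c(N)cc5nc6ccccc6nc5c43)c3ccccc32)cc1` has a different core from compound 2; how the two cores differ is not broken down here. In this assay compound 3 gives > 50000 nM, which is likewise a limit. Compound 4 `CCOc1ccccc1-n1nncc1CN1C(=O)C2(C(C#N)=C(N)Oc3c(N)cc4nc5ccccc5nc4c32)c2ccccc21` has not yet been measured; it differs from compound 3 by 2-ethoxyphenyl in place of 4-ethoxyphenyl on an aromatic nitrogen, the same change as that from compound 2 to compound 1, made at the same place.

For the measured compounds named here, because of the limit of > 50000 nM in this assay, at which 3 of the 3 values shown sit, no step could be sized, and the step that the estimate for compound 4 means, a number no higher from compound 3 to compound 4 (the limit leaves the size open), is expected to be negligible. Compound 4 is therefore expected to give about 50000 nM in this assay, most likely again only a limit, with an expected range from 20000 nM to 100000 nM.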

Compound 4, half-maximal inhibitory concentration: 30500 nM
For compound 4 the middle estimate is 1.6-fold (0.21 log units) above the measured one, within the range that was stated.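

In this assay, for the compounds shown here, placing 2-ethoxyphenyl in place of 4-ethoxyphenyl on the core of compound 3 gave an at least 1.6-fold lower number from compound 3 to compound 4 (0.21 log units; that floor lies within the scatter), the only step that has any readable size. Going by these compounds alone, this does not establish a change beyond the usual scatter on this core, although the true size of the step remains open and compound 4 is the only one of the four compounds with a number rather than a limit. Nor does it show that the change carries from one core to the other, since the same change on the core of compound 2 cannot be read and the two steps cannot be compared, for the following reason: the limit of > 50000 nM in this assay, at which 3 of the 4 values shown sit.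

The compounds shown leave open what a methoxy group, a longer alkoxy chain or an amine would do on the phenyl ring in place of the ethoxy group, on either core. They also leave open how compound 1 and compound 2 stand relative to each other, and whether the 2-ethoxyphenyl group would give a number on the core they share.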